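Changing the Aryl Group on the Amide-Type Nitrogen

The source may hold more compounds than are shown below. What is called first, only, known or untested is meant among the compounds shown, and "the series" means these compounds.

Three measured compounds share one core and differ only in the ring attached to one amide-type nitrogen. Compound 1 `COc1ccc(NC(=O)Nc2cccc(CNc3ncnc4ccccc34)c2)cc1` gives 27300 nM in a functional assay on MGC-803 cells (Homo sapiens) for antiproliferative activity, read by MTT assay; on this read-out lower numbers stand for stronger inhibition and higher numbers for weaker inhibition. Compound 2 `O=C(Nc1cccc(CNc2ncnc3ccccc23)c1)Nc1ccccc1F` gives 33400 nM in this assay, and compound 3 `O=C(Nc1ccc(F)cc1)Nc1cccc(CNc2ncnc3ccccc23)c1` gives 44300 nM. The spread is narrow: a 1.2-fold higher number from compound 1 to compound 2 (0.09 log units; within the scatter), a 1.6-fold higher number from compound 1 to compound 3 (0.21 log units; within the scatter) and a 1.3-fold higher number from compound 2 to compound 3 (0.12 log units; within the scatter). Compound 3 therefore stands among the others without separating from either of them.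

Compound 4 `O=C(Nc1cccc(Cl)c1)Nc1cccc(CNc2ncnc3ccccc23)c1` differs from compound 3 in one place: 3-chlorophenyl in place of 4-fluorophenyl on an amide-type nitrogen. Going by the values given here, two measured steps bear on this. Moving from one fluorophenyl to another gave a 1.3-fold higher number from compound 2 to compound 3 (0.12 log units; within the scatter), and exchanging methoxy for fluoro gave a 1.6-fold higher number from compound 1 to compound 3 (0.21 log units; within the scatter); neither shifted the number beyond the scatter. Exchanging one halogen-bearing phenyl for another is therefore expected to give a similarly small step, a 1.1-fold lower number from compound 3 to compound 4 (0.04 log units; within the scatter), with no direction that can be called. The expected value for compound 4 is 40000 nM, within a range from 15000 nM to 100000 nM.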

Compound 4, half-maximal inhibitory concentration: 19200 nM
Beside the measured number, compound 4's estimate is 2.1-fold (0.32 log units) above it; the measured number falls inside the stated range.
By their numbers in this assay, from the lowest: compounds 4, 1, 2 and 3 (each within the scatter of the next, the first and the last beyond it).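

In this assay the ring on this amide-type nitrogen can move the number beyond the usual scatter: 3-chlorophenyl in place of 4-fluorophenyl gives a modest step (a 2.3-fold lower number from compound 3 to compound 4 (0.36 log units; beyond the scatter)), the first shown here to pass it. The two other exchanges that end in 3-chlorophenyl stay within the scatter (a 1.7-fold lower number from compound 2 to compound 4 (0.24 log units; within the scatter); a 1.4-fold lower number from compound 1 to compound 4 (0.15 log units; within the scatter)), so compound 4 separates from compound 3 alone. No measurement shown here speaks to why this step occurs.

Compound 3 and compound 4 differ in both the halogen and its place on the ring, so the contribution of each cannot be told apart. As far as these compounds go, whether an amine, a carboxylic acid or a longer chain on this ring would shift the number remains open.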